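Amide for amine: a step on the indole carboxylic acid

This account rests on a few compounds, and the source may have more. Where it says the series, first, only, none or still open, it means among the compounds named here.

Measured compounds:
compound 1 `COc1ccc(Cn2c(C(=O)O)c(CN(C)Cc3cccc(OC)c3)c3ccc(C)cc32)cc1`, 33000 nM
compound 2 `COc1ccc(Cn2c(C(=O)O)c(CNCc3cccc(OC)c3)c3ccc(C)cc32)cc1`, 9830 nM

For the measured compounds named here, in a functional assay on Bel-7402 cells (Homo sapiens) for antiproliferative activity, read by MTT assay, with a stated time of 72 h (on this read-out higher numbers stand for weaker inhibition and lower numbers for stronger inhibition), compound 2 stands lowest of the two numbers; the only measured step, a 3.4-fold lower number from compound 1 to compound 2 (0.53 log units; beyond the scatter), concerns the same amine nitrogen. Compound 3 `COc1ccc(Cn2c(C(=O)O)c(CNC(=O)c3cccc(OC)c3)c3ccc(C)cc32)cc1` differs from compound 2 by (3-methoxyphenyl)carbonyl in place of 3-methoxybenzyl on an amine nitrogen. Going by the values given here, no measured step covers an amide in place of an amine here, so the direction is uncertain; the estimate for compound 3 is therefore centred near compound 2 with a wide range, at 15000 nM (range 4000 nM to 60000 nM), which is the expected step of a 1.5-fold higher number from compound 2 to compound 3 (0.18 log units; within the scatter).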

Compound 3, half-maximal inhibitory concentration: > 50000 nM
Compound 3: a limit, no number; the forecaster's own chance of this, stated with the estimate: 15%; middle value at least 3.3-fold (0.52 log units) from the limit.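

In this assay, compound 3 gives a limit and not a number: the limit of > 50000 nM in this assay, at which 1 of the 3 values shown sits. Placing (3-methoxyphenyl)carbonyl instead of 3-methoxybenzyl on this amine nitrogen weakens inhibition, with an at least 5.0-fold higher number from compound 2 to compound 3 (0.70 log units; beyond the scatter), so the change to an amide, unlike hydrogen in place of methyl on the same nitrogen, with a 3.4-fold lower number from compound 1 to compound 2 (0.53 log units; beyond the scatter), does not favour activity here. Replacing (3-methoxybenzyl)(methyl)amino with ((3-methoxyphenyl)carbonyl)amino gives an at least 1.5-fold higher number from compound 1 to compound 3 (0.18 log units; that floor lies within the scatter). Going by these compounds, whether a sulfonamide or a urea on this nitrogen would behave like the amine of compound 2 or the amide of compound 3 stays open.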